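The source may report more compounds than this note shows. Statements on the series, on what has been measured and on what is new or still open speak of the compounds shown alone.

Measured so far in an ADME assay on WI-38 cells (Homo sapiens) for inhibition, read by MTT assay, with a stated time of 72 h; a higher number here means a weaker inhibitor, a lower number a stronger inhibitor:
compound 1 `Nc1ccn(C[C@H](O)[C@H]2OC(=O)C(OCc3ccccc3)=C2OCc2ccccc2)c(=O)n1`, which gives 53900 nM
compound 2 `Nc1ccn(CCC2(N)OC(=O)C(OCc3ccccc3)=C2OCc2ccccc2)c(=O)n1`, which gives 88900 nM
compound 3 `NC1(CCn2c(=O)[nH]c(=O)[nH]c2=O)OC(=O)C(OCc2ccccc2)=C1OCc1ccccc1`, for which only a limit of the assay is reported, > 100000 nM

The difference between the core of compound 1 and the core of compound 2 is not broken down here. In this assay compound 1 and compound 2 lie within the usual scatter of each other, so no order between them is claimed.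

From compound 2 to compound 3 the change is a group of 9 heavy atoms (3 carbon, 3 nitrogen, 3 oxygen; one six-membered aromatic ring with 3 hetero atoms) in place of a group of 8 heavy atoms (4 carbon, 3 nitrogen, 1 oxygen; one six-membered aromatic ring with 2 hetero atoms), on a saturated chain carbon, two bonds along the chain from a saturated ring carbon. The step is an at least 1.1-fold higher number from compound 2 to compound 3 (0.05 log units; that floor lies within the scatter), and its size is only a floor, because compound 3 sits at the limit of > 100000 nM in this assay, at which 1 of the 3 values shown sits.

Compound 4 `O=C1O[C@H]([C@@H](O)Cn2c(=O)[nH]c(=O)[nH]c2=O)C(OCc2ccccc2)=C1OCc1ccccc1` is not yet measured. It differs from compound 1 by a group of 9 heavy atoms (3 carbon, 3 nitrogen, 3 oxygen; one six-membered aromatic ring with 3 hetero atoms) in place of a group of 8 heavy atoms (4 carbon, 3 nitrogen, 1 oxygen; one six-membered aromatic ring with 2 hetero atoms), on a saturated chain carbon, two bonds along the chain from an oxygen on a saturated carbon and a saturated ring carbon. This is the same kind of change as that from compound 2 to compound 3, not the same change: around the place, compound 4 has in addition an oxygen on a saturated carbon two bonds along the chain.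

For compound 4 the expected step in this assay is a 1.8-fold higher number from compound 1 to compound 4 (0.25 log units; within the scatter), resting on compound 1 at 53900 nM. It also rests on the measured step of an at least 1.1-fold higher number from compound 2 to compound 3 (0.05 log units; that floor lies within the scatter), whose floor lies within the scatter and leaves the true size open. The estimate for compound 4 is 95000 nM, expected between 45000 nM and 250000 nM, with a fair chance that this assay again reports only a limit for compound 4.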

Compound 4, half-maximal inhibitory concentration: > 100000 nM
Compound 4 gave a limit, no number (the forecaster's own chance of this, stated with the estimate: 45%); middle value at least 1.0-fold (0.02 log units) away from the limit.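

In this assay, compound 4 gives only a limit of the assay, > 100000 nM. Putting the group with a six-membered aromatic ring with 3 hetero atoms in place of the group with a six-membered aromatic ring with 2 hetero atoms, on the saturated chain carbon, gives an at least 1.8-fold higher number from compound 1 to compound 4 (0.26 log units; that floor lies within the scatter), and set beside the earlier step this reads: the same change on two cores in this assay, an at least 1.1-fold higher number (0.05 log units; that floor lies within the scatter) from compound 2 to compound 3 and an at least 1.8-fold higher number (0.26 log units; that floor lies within the scatter) from compound 1 to compound 4; the limit leaves it open whether they differ What this shows is only that neither core yields a number for the entering group, so the change can be carried from one core to the other without a measured value appearing, while it does not show a size for the change on either core, nor whether the size depends on the core: the limit of > 100000 nM in this assay, at which 2 of the 4 values shown sit.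

The compounds shown leave open whether any compound with the entering group gives a true number in this assay, and so whether the change has any real effect at all. Also open, on these data alone, is what a longer chain between the ring and the core, or a carboxylic acid in place of the ring, would give in this assay, since the series here holds only the two ring groups on a short chain.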